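Pyridinylmethyl for fluorobenzyl on a weak meta-amide analogue

The source may hold more compounds than are shown below. What is called first, only, known or untested is meant among the compounds shown, and "the series" means these compounds.

Working notes on a small set sharing one sulfamate core. Compound 1 `CCN(Cc1ccc(Br)cc1)c1ccc(C(=O)N2CCc3ccc(OS(N)(=O)=O)cc3C2)cc1` gives 78.2% in an assay on HEK293 cells for inhibition of Steryl-sulfatase (Homo sapiens), tested at 0.1 uM; a lower number here means a weaker effect, a higher number a stronger effect of the compound at the concentration tested. Compound 2 `CCN(Cc1ccc(F)cc1)c1cccc(C(=O)N2CCc3ccc(OS(N)(=O)=O)cc3C2)c1` gives 10.9% in this assay, and compound 3 `CN(C)CCN(Cc1ccccc1)c1ccc(C(=O)N2CCc3ccc(OS(N)(=O)=O)cc3C2)cc1` gives 13.9% in this assay. Compound 2 thus sits at the bottom of the three numbers, but its gap to compound 3 is within the scatter, so the two cannot be told apart; only compound 1 stands clearly above it, by a margin well beyond the scatter.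

Compound 4 `CCN(Cc1ccccn1)c1cccc(C(=O)N2CCc3ccc(OS(N)(=O)=O)cc3C2)c1` is the next member awaiting measurement. Its difference from compound 2 is pyridin-2-yl in place of 4-fluorophenyl on a saturated chain carbon bound to a nitrogen on an aromatic ring. Among the measured compounds shown here, no pair already measured isolates this change, so its size has to be guessed rather than read from a measured step.

Compound 4 is expected to stay close to compound 2 because 10.9% leaves little room downward and nothing among the three measured compounds points to a large gain from swapping one aromatic ring on that chain carbon for another. The step of a number 3.1 percentage points higher from compound 2 to compound 4 (within the scatter) is therefore expected to fall within the scatter, with a modest rise the more likely direction if any. The estimate for compound 4 in this assay is 14%, with a plausible range from 3% to 32%.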

Compound 4, a percentage reported as inhibition, at one concentration (the size of the read-out at that concentration, not a potency): 6.5%
Compound 4: middle estimate off by 7.5 percentage points, on the high side; the range from low to high includes it.
By their numbers in this assay, from the lowest: compounds 4, 2 and 3 (each within the scatter of the next); then compound 1.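

In this assay, among the compounds shown here, the replacement of 4-fluorophenyl by pyridin-2-yl on a saturated chain carbon bound to a nitrogen on an aromatic ring gives the first measured step at this place, a number 4.4 percentage points lower from compound 2 to compound 4 (within the scatter). The two compounds therefore cannot be told apart, and exchanging the carbon-only ring for one with a hetero atom and a hydrogen-bond acceptor produces no resolved change in the read-out on this background; with both numbers so low, a further loss would also be hard to detect. Nothing at hand accounts for the size of this step or for the low level of either compound.

Still open, going by these compounds, is whether this same replacement would leave the read-out unchanged on a stronger background such as compound 1, where a clear loss could be seen. Also open, on these data alone, is whether a different group at this place, such as pyridin-4-yl, a carboxylic acid on the aromatic ring or a longer chain ending in an amine, would separate from compound 2 by more than the scatter.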